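Aryl group exchange on a triazole-linked spiro series

This account rests on a few compounds, and the source may have more. Where it says the series, first, only, none or still open, it means among the compounds named here.

Compound 1 `CC(=O)Nc1ccc(-n2nncc2CN2C(=O)C3(C(C#N)=C(N)Oc4c(N)cc5nc6ccccc6nc5c43)c3ccccc32)cc1`: > 50000 nM
Compound 2 `Cc1ccc(C)c(-n2nncc2CN2C(=O)C3(C(C#N)=C(N)Oc4c(N)cc5nc6ccccc6nc5c43)c3ccccc32)c1`: > 50000 nM

In a functional assay on HCT-116 cells (Homo sapiens) for antiproliferative activity, read by MTT assay, with a stated time of 48 h (a higher number here means a weaker inhibitor, a lower number a stronger inhibitor), compound 1 gives only a limit, > 50000 nM. In this assay compound 2 likewise gives only a limit, > 50000 nM. Both values are limits of the measurement rather than numbers, and both compounds sit at the limit of > 50000 nM in this assay, at which 2 of the 2 values shown sit. Compound 2 therefore stands at the limit, with no known number of its own. Within the data shown here, the one measured step, a step that the two limits leave unreadable from compound 1 to compound 2, is a change of the same kind at the same place as the one considered here, yet its size cannot be read.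

Compound 3 `CCc1cccc(CC)c1-n1nncc1CN1C(=O)C2(C(C#N)=C(N)Oc3c(N)cc4nc5ccccc5nc4c32)c2ccccc21` differs from compound 2 by 2,6-diethylphenyl in place of 2,5-dimethylphenyl on an aromatic nitrogen. With only an unreadable step to draw on, no size or direction is expected beyond the scatter; the expected step is a step that the limit leaves unreadable from compound 2 to compound 3, that is, none that can be read. Compound 3 is estimated at 80000 nM, within 30000 nM to 300000 nM, and is most likely reported again as a limit only.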

Compound 3, half-maximal inhibitory concentration: 37600 nM
Estimate against measurement, compound 3: 2.1-fold (0.33 log units) above; measured number inside the range.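

In this assay, this aryl position now yields a measured number rather than a limit, and it does so with 2,6-diethylphenyl in compound 3. The exchange gives an at least 1.3-fold lower number from compound 2 to compound 3 (0.12 log units; that floor lies within the scatter) and an at least 1.3-fold lower number from compound 1 to compound 3 (0.12 log units; that floor lies within the scatter); each is only a floor, so the true steps could be larger, but neither shows a gain beyond the scatter. Only floors can be read, because the values of the other two compounds are limits and not numbers: the limit of > 50000 nM in this assay, at which 2 of the 3 values shown sit.

Compound 3 differs from compound 2 in both the chain on the phenyl ring and where the chains sit, so the compounds shown cannot separate these two changes. As far as these compounds go, it also remains open how a phenyl ring bearing an amine, a carboxylic acid or a longer chain such as propyl would read in this assay.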